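Moving One Fluorine from Compound 1 to Compound 4

The source may hold more compounds than are shown below. What is called first, only, known or untested is meant among the compounds shown, and "the series" means these compounds.

Among the compounds with values here, in a functional assay on SW480 cells (Homo sapiens) for antiproliferative activity, with a stated time of 72 h (a lower number here means a stronger inhibitor, a higher number a weaker inhibitor), compound 1 `O=C(COc1ccc(CNC2CC=C(c3c[nH]c4cccc(F)c34)CC2)c(F)c1)NO` gives 189 nM and so holds the lower of the two actual numbers so far. Compound 2 `Cc1[nH]c2ccccc2c1C1=CCN(Cc2ccc(OCC(=O)NO)cc2)CC1` gives 697 nM in this assay and its gap to compound 1 lies beyond the usual scatter. Compound 3 `O=C(COc1ccc(C(=O)NC2CC=C(c3c[nH]c4cccc(F)c34)CC2)cc1)NO` returned > 5000 nM as a limit and not as a number.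

Compound 4 `O=C(COc1ccc(CNC2CC=C(c3c[nH]c4ccc(F)cc34)CC2)c(F)c1)NO` has the same atoms as compound 1 joined differently, with 5-fluoro-1H-indol-3-yl in place of 4-fluoro-1H-indol-3-yl on a double-bonded ring carbon and the rest of the molecule unchanged. Within the data shown here, no measured pair shows what moving this fluorine does, so the forecast is a cautious one. In this assay a small move toward a higher number seems most likely, with nothing beyond the scatter. The estimated step of a 1.4-fold higher number from compound 1 to compound 4 (0.14 log units; within the scatter) starts from compound 1 at 189 nM and remains modest. The expected value for compound 4 is 260 nM with an estimated range of 90 nM to 750 nM when it is measured.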

Compound 4, half-maximal inhibitory concentration: 179 nM
For compound 4 the middle estimate is 1.5-fold (0.16 log units) above the measured one; the measured number falls inside the stated range.
By their numbers in this assay, from the lowest: compounds 4 and 1 (each within the scatter of the next); then compound 2. At a limit, above all of these: compound 3.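

In this assay, within the data shown here, 5-fluoro-1H-indol-3-yl in place of 4-fluoro-1H-indol-3-yl on the double-bonded ring carbon gives a 1.1-fold lower number from compound 1 to compound 4 (0.02 log units; within the scatter) and so provides the first direct reading of this change. The earlier compounds shown here could not show this, since none of them formed a pair differing in one place. The fluorine can take either of these two places on the group with no change that stands out from the scatter, and nothing measured here bears on why the two compounds read alike.

Still open, going by these compounds, is whether this group needs a fluorine at all, as the plain 1H-indol-3-yl group would show. Also open, on these data alone, is whether a chlorine atom or a methoxy group in the same two places would read like fluorine in this assay.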